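This account rests on a few compounds, and the source may have more. Where it says the series, first, only, none or still open, it means among the compounds named here.

Compound 1 `COc1ccc(/C=C/c2nc(NCCN3CCCCC3)c3ccccc3n2)cc1OC`: 19800 nM
Compound 2 `COc1ccc(/C=C/c2nc(NCCN(C)C)c3cc(Cl)ccc3n2)cc1OC`: 80500 nM
Compound 3 `COc1ccc(/C=C/c2nc(NCCN(C(C)C)C(C)C)c3cc(Cl)ccc3n2)cc1OC`: > 100000 nM
Compound 4 `COc1ccc(/C=C/c2nc(NCCN3CCCCC3)c3cc(Cl)ccc3n2)cc1OC`: not yet measured

In a functional assay on L02 cells (Homo sapiens) for cytotoxicity, read by MTT assay, with stated times of 48 h and 4 h (on this read-out lower numbers stand for stronger inhibition and higher numbers for weaker inhibition), compound 3 gives only a limit, > 100000 nM, and not a number. Compound 4 differs from it as follows: piperidin-1-yl in place of diisopropylamino on a saturated chain carbon, two bonds along the chain from a nitrogen on an aromatic ring. Piperidin-1-yl takes the place of diisopropylamino on a saturated chain carbon. Among the compounds with values here, the one measured step at this place, an at least 1.2-fold higher number from compound 2 to compound 3 (0.09 log units; that floor lies within the scatter), is small and rests on that limit. Compound 1 also carries piperidin-1-yl and gives 19800 nM, which points towards a lower number for compound 4. A modest step is therefore expected, an at least 1.6-fold lower number from compound 3 to compound 4 (0.22 log units; that floor lies within the scatter). Compound 4 is estimated at 60000 nM, with an expected range of 22000 nM to 120000 nM.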

Compound 4, half-maximal inhibitory concentration: 13900 nM
Compound 4: the middle estimate sits 4.3-fold (0.64 log units) above what was measured; the measured number lies below the stated range.
By their numbers in this assay, from the lowest: compounds 4 and 1 (each within the scatter of the next); then compound 2. At a limit, above all of these: compound 3.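

In this assay the group on this saturated chain carbon now proves to matter: piperidin-1-yl in place of dimethylamino gives a 5.8-fold lower number from compound 2 to compound 4 (0.76 log units; beyond the scatter) and piperidin-1-yl in place of diisopropylamino gives an at least 7.1-fold lower number from compound 3 to compound 4 (0.85 log units; beyond the scatter) as well. The second step has only a limit as its starting point, since compound 3 gives no number: the limit of > 100000 nM in this assay, at which 1 of the 4 values shown sits. Chloro in place of hydrogen on an aromatic carbon gives a 1.4-fold lower number from compound 1 to compound 4 (0.15 log units; within the scatter) and so shows no change beyond the scatter.

The compounds shown leave open whether the lower number needs piperidine itself. A morpholine or pyrrolidine ring at this place, or a longer chain, would test that.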